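The compounds below may be only part of what the source reports. "The series", "measured", "known", "first", "only" and "open" are said of these compounds alone.

Three compounds sharing one core have been examined in a functional assay on MCF7 cells (Homo sapiens) for antiproliferative activity, read by CCK-8 assay, with a stated time of 72 h (on this read-out lower numbers stand for stronger inhibition and higher numbers for weaker inhibition), differing only in the aryl group attached to the carbonyl carbon of the amide. Compound 1 `Cc1ccccc1C(=O)Nc1cccc(-c2oc3cc(-c4ccc(F)cc4)ccc3c(=O)c2O)c1` gives 2280 nM, compound 2 `O=C(Nc1cccc(-c2oc3cc(-c4ccc(F)cc4)ccc3c(=O)c2O)c1)c1ccc(C(F)(F)F)cc1` gives 32600 nM, and compound 3 `Cc1cccc(C(=O)Nc2cccc(-c3oc4cc(-c5ccc(F)cc5)ccc4c(=O)c3O)c2)c1` gives 7850 nM. Compound 3 therefore stands second highest of the three numbers: in this assay it sits a 3.4-fold higher number from compound 1 to compound 3 (0.54 log units; beyond the scatter), and a 4.2-fold lower number from compound 2 to compound 3 (0.62 log units; beyond the scatter). Across the widest gap, a 14-fold higher number from compound 1 to compound 2 (1.16 log units; beyond the scatter).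

Compound 4 `CCCc1ccc(C(=O)Nc2cccc(-c3oc4cc(-c5ccc(F)cc5)ccc4c(=O)c3O)c2)cc1` is the next member: 4-propylphenyl in place of 3-methylphenyl on a carbonyl carbon. Two of the steps already seen bear on this move. Among the measured compounds shown here, the step from compound 1 to compound 3 was modest, and the step from compound 2 to compound 3 was also modest, where compound 2 is the only other member carrying its group as a 4-substituted phenyl, namely 4-(trifluoromethyl)phenyl. Since compound 2 gave the highest number, 32600 nM, and a move from a 3-methylphenyl to another group on the same carbonyl carbon has twice shifted the number beyond the scatter, a further rise in this assay is expected for compound 4, of modest size, a 1.7-fold higher number from compound 3 to compound 4 (0.22 log units; within the scatter). The estimate for compound 4 is 13000 nM, expected to fall between 4000 nM and 40000 nM.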

Compound 4, half-maximal inhibitory concentration: 36800 nM
Compound 4: middle estimate off by 2.8-fold (0.45 log units), on the low side, within the range that was stated.
By their numbers in this assay, from the lowest: compound 1; then compound 3; then compounds 2 and 4 (each within the scatter of the next).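

In this assay, moving from 3-methylphenyl to 4-propylphenyl on the carbonyl carbon gives a 4.7-fold higher number from compound 3 to compound 4 (0.67 log units; beyond the scatter), so a second 4-substituted phenyl group now sits at the high end of the series. Propyl in place of trifluoromethyl on the aromatic carbon gives a 1.1-fold higher number from compound 2 to compound 4 (0.05 log units; within the scatter), which shows for the first time that two quite different groups at the same place on this ring can give numbers that cannot be told apart. Among the compounds shown here, the 2-methylphenyl group of compound 1 keeps the lowest number, and the step to the new member, a 16-fold higher number from compound 1 to compound 4 (1.21 log units; beyond the scatter), is as wide as any, with no compound among the four going against this ordering of 2-methylphenyl, 3-methylphenyl and the 4-substituted groups. Nothing given here accounts for these shifts.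

Compound 4 differs from compound 3 both in where its group sits on the ring and in the chain it carries, so the two changes cannot be separated, and a 4-methylphenyl group would be needed to part them. On these data alone, it also remains open whether an amine or a carboxylic acid on that ring, in place of the propyl chain, would give a number as high as these.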